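Amino in place of methoxy: next step from compound 2

The source may report more compounds than this note shows. Statements on the series, on what has been measured and on what is new or still open speak of the compounds shown alone.

Within the data shown here, compound 2 `COc1ccc(Nc2nc3ccccc3nc2S(=O)(=O)c2ccc(OC)cc2)cc1` stands highest of the two numbers measured so far in a functional assay on PC-3 cells (Homo sapiens) for cytotoxicity, read by MTT assay, with a stated time of 72 h; on this read-out higher numbers stand for weaker inhibition and lower numbers for stronger inhibition: in this assay compound 2 gives 8710 nM. Its nearest neighbour is compound 1 `COc1ccc(S(=O)(=O)c2nc3ccccc3nc2Nc2ccccc2)cc1`, which in this assay gives 1260 nM; the step of a 6.9-fold higher number from compound 1 to compound 2 (0.84 log units; beyond the scatter) is modest but beyond the scatter and consists of methoxy in place of hydrogen on an aromatic carbon.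

Compound 3 `COc1ccc(S(=O)(=O)c2nc3ccccc3nc2Nc2ccc(N)cc2)cc1` is not yet measured. It differs from compound 2 by amino in place of methoxy on an aromatic carbon, that is, (4-methoxyphenyl)amino to (4-aminophenyl)amino. Among the measured compounds shown here, no measured step shows amino at this aromatic carbon; the only step that bears on it is the one from compound 1 to compound 2, which shows that placing methoxy there raises the number. As far as these compounds go, removing that methoxy could plausibly move the number back toward compound 1, but what amino adds in its place is unknown, so the direction is uncertain. Compound 3 is therefore expected to lie somewhat below compound 2, with the step of a 2.2-fold lower number from compound 2 to compound 3 (0.34 log units; beyond the scatter), and the estimate for compound 3 is 4000 nM, within a range of 1300 nM to 12000 nM.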

Compound 3, half-maximal inhibitory concentration: 9640 nM
Beside the measured number, compound 3's estimate is 2.4-fold (0.38 log units) below it, within the range that was stated.
By their numbers in this assay, from the lowest: compound 1; then compounds 2 and 3 (each within the scatter of the next).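

In this assay, amino in place of methoxy on this aromatic carbon gives a 1.1-fold higher number from compound 2 to compound 3 (0.04 log units; within the scatter), so compound 2 and compound 3 cannot be separated, even though the two groups differ in heavy atoms and hydrogen-bond donors. Amino in place of hydrogen at the same carbon gives a 7.7-fold higher number from compound 1 to compound 3 (0.88 log units; beyond the scatter), which sits alongside a 6.9-fold higher number from compound 1 to compound 2 (0.84 log units; beyond the scatter): among these three compounds, both substituted compounds give higher numbers than the unsubstituted compound 1, and neither goes against this, so the rise no longer rests on methoxy alone. No supporting data are available to explain why the two groups cannot be told apart at this carbon.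

The compounds shown leave open whether any group on this carbon gives the same rise, or whether a chloro group, a carboxylic acid or a longer chain such as ethoxy would fall elsewhere relative to compound 1. They also leave open whether the shared rise is tied to this carbon, since both substituted compounds carry their group at the same place on the ring.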